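The compounds below may be only part of what the source reports. "The series", "measured", "known", "first", "only" and "open" are said of these compounds alone.

Measured so far:

Compound 1 `C=C1CCC(c2csc(/C=C(\C)C(N)=O)c2)CC1`: in a functional assay on BGC-823 cells (Homo sapiens) for cytotoxicity, read by CCK-8 assay, with a stated time of 24 h (a lower number here means a stronger inhibitor, a higher number a weaker inhibitor), compound 1 gives > 50000 nM, which is a limit of the assay rather than a number.
Compound 2 `C/C(=C\c1cccc(-c2ccc(C)cc2)c1)C(N)=O`: compound 2 gives > 50000 nM, again a limit.
Compound 3 `C/C(=C\c1cc(-c2ccc(C#N)cc2)cs1)C(N)=O`: compound 3 gives > 50000 nM, also a limit.

Compound 3 therefore stands nowhere in particular among the numbers shown, since every value recorded so far is the same limit: the limit of > 50000 nM in this assay, at which 3 of the 3 values shown sit. For the measured compounds named here, none of the three compounds has produced a measurable half-maximal inhibitory concentration, so no step between measured compounds can be drawn, and no compound can be called stronger or weaker than another.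

The next compound is compound 4 `C=Cc1ccc(-c2csc(/C=C(\C)C(N)=O)c2)cc1`. It differs from compound 3 in a single place: vinyl in place of cyano on an aromatic carbon, in words, vinyl in place of cyano on an aromatic carbon. The rest of the molecule, including the shared core and the amide-bearing side chain, is unchanged.

Going by the values given here, with no measured step to lean on and all three values sitting at the limit, no step beyond the usual scatter is expected in this assay from compound 3 to compound 4, and the step is estimated as a number no higher from compound 3 to compound 4 (the limit leaves the size open). Compound 4 is expected to give about 50000 nM, in a range from 20000 nM to 100000 nM, most likely reported as a limit.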

Compound 4, half-maximal inhibitory concentration: > 50000 nM
Compound 4: a limit, no number; the forecaster's own chance of this, stated with the estimate: 85%; the middle value sits exactly at the limit.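

Compound 4 gives > 50000 nM, which is a limit and not a number. Compound 3 sits at the same limit, and no step can be read between compound 3 and compound 4, with vinyl in place of cyano. The compounds shown leave open how strong any of them really is, and whether any change to them would give a measurable value, because all of them stand at one limit: the limit of > 50000 nM in this assay, at which 4 of the 4 values shown sit.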